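Methoxy to tert-butyl on the aryl arm of compound 3

A few compounds are considered here, and "the series" means these few. Any claim that something is new, unique, unknown or untested is made for them only; others in the source may bear on it.

Measured so far in an ADME assay on HepG2 cells (Homo sapiens) for cytotoxicity, read by luminescence, CellTiter-Glo and ATP content, with a stated time of 72 h; on this read-out lower numbers stand for an effect already at smaller amounts and higher numbers for an effect only at larger amounts of compound:
- compound 1, `CC(C)(C)c1ccc(-c2ccc3c(NCCCNCc4ccco4)ccnc3c2)cc1`: 3150 nM
- compound 2, `COc1ccc(F)cc1CNCCCNc1ccnc2cc(Oc3cccc(N(C)C)c3)ccc12`: 3300 nM
- compound 3, `COc1ccc(-c2ccc3c(NCCCNCc4cc(F)ccc4OC)ccnc3c2)cc1`: 5960 nM

The three measured values sit close together. Compound 3 is separated from compound 2 by a 1.8-fold higher number from compound 2 to compound 3 (0.26 log units; within the scatter), and its gap to compound 1 is likewise within the scatter, so no ordering among the three can be read from these numbers.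

Compound 4, `COc1ccc(F)cc1CNCCCNc1ccnc2cc(-c3ccc(C(C)(C)C)cc3)ccc12`, differs from compound 3 by tert-butyl in place of methoxy on an aromatic carbon. It thereby carries the same 4-(tert-butyl)phenyl group that compound 1 bears on the shared core, but with the amine chain of compound 2 and compound 3.

Among the compounds with values here, only one measured step touches this position, the change from compound 2 to compound 3, and it stayed within the scatter. Compound 1 and compound 3 share the core and the chain length but differ at two places, so their two values can only be noted side by side: both lie within the scatter of each other. Nothing in this set points to a shift beyond the scatter for tert-butyl in place of methoxy, and the expected step from compound 3 to compound 4 is therefore small, a 1.4-fold lower number from compound 3 to compound 4 (0.15 log units; within the scatter). In this assay compound 4 is estimated at 4200 nM, with a range from 1800 nM to 9500 nM.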

Compound 4, half-maximal effective concentration: 620 nM
For compound 4 the middle estimate is 6.8-fold (0.83 log units) above the measured one, and the stated range ends above it.
By their numbers in this assay, from the lowest: compound 4; then compounds 1, 2 and 3 (each within the scatter of the next).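

In this assay, within the data shown here, tert-butyl on this aromatic carbon produces the first single change in the set that lies beyond the scatter, with a 9.6-fold lower number from compound 3 to compound 4 (0.98 log units; beyond the scatter) on a swap that adds only carbon atoms and removes the one hydrogen-bond acceptor of the methoxy group, while the earlier step of a 1.8-fold higher number from compound 2 to compound 3 (0.26 log units; within the scatter) stayed within it. The same arm also separates compound 4 from the phenoxy-linked compound, with a 5.3-fold lower number from compound 2 to compound 4 (0.73 log units; beyond the scatter) for 4-(tert-butyl)phenyl in place of 3-(dimethylamino)phenoxy, yet that arm alone does not give the low number: compound 1 carries it too, and a 5.1-fold lower number from compound 1 to compound 4 (0.71 log units; beyond the scatter) follows from 5-fluoro-2-methoxyphenyl in place of furan-2-yl at the amine end. Among these four compounds the low number therefore appears only where 4-(tert-butyl)phenyl and the 5-fluoro-2-methoxyphenyl amine end occur together, and no measurement shown here explains the shift.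

Open, going by these compounds, is whether this drop belongs to tert-butyl specifically or would also appear with isopropyl, trifluoromethyl or a carboxylic acid on the same aromatic carbon. Also open, on these data alone, is whether the pairing holds with a longer chain between the two amine nitrogens or with other aryl groups at the amine end.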